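Amine side chain variation in a small series

The source may hold more compounds than are shown below. What is called first, only, known or untested is meant among the compounds shown, and "the series" means these compounds.

Measured so far:
compound 1 `C=CCNc1nnc(SCC(=O)N(Cc2cccc([N+](=O)[O-])c2)c2ccc(F)cc2)s1` in an assay on isolated protein for inhibition of Amine oxidase [flavin-containing] A (Homo sapiens), read by fluorescence and Amplex Red, with a stated time of 30 min, tested at 0.1 nM; a higher number here means a stronger effect of the compound at the concentration tested, a lower number a weaker effect: 13.5%
compound 2 `COCCNc1nnc(SCC(=O)N(Cc2cccc([N+](=O)[O-])c2)c2ccc(F)cc2)s1` in this assay: 20.1%

For the measured compounds named here, compound 2 gives the higher of the two numbers recorded, but the only comparison available, compound 1, sits close by and the step between them is within the scatter. In this assay the step of a number 6.6 percentage points higher from compound 1 to compound 2 (within the scatter) therefore carries no direction that can be trusted.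

The next compound, compound 3 `CCCNc1nnc(SCC(=O)N(Cc2cccc([N+](=O)[O-])c2)c2ccc(F)cc2)s1`, differs from compound 2 by methyl in place of methoxy on a saturated chain carbon, two bonds along the chain from a nitrogen on an aromatic ring. Going by the values given here, this is a change on the same amine side chain as the one step already measured, and that step was within the scatter. Among the compounds with values here, nothing so far points to a step beyond the scatter for this kind of change on this chain; the outcome is expected to remain close to compound 2.

Compound 3 is expected to give 17%, with a range from 7% to 28%. The estimated step is a number 3.1 percentage points lower from compound 2 to compound 3 (within the scatter), which is within the scatter.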

Compound 3, a percentage reported as inhibition, at one concentration (the size of the read-out at that concentration, not a potency): 12%
Compound 3: the middle estimate sits 5 percentage points above what was measured, within the range that was stated.
By their numbers in this assay, from the lowest: compounds 3, 1 and 2 (each within the scatter of the next).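

In this assay, methyl in place of methoxy on a saturated chain carbon, two bonds along the chain from a nitrogen on an aromatic ring, gives a number 8.1 percentage points lower from compound 2 to compound 3 (within the scatter). Ethyl in place of vinyl on a saturated chain carbon bound to a nitrogen on an aromatic ring gives a number 1.5 percentage points lower from compound 1 to compound 3 (within the scatter). With the propyl chain added, neither the methoxy group nor the vinyl end separates from the plain alkyl chain at this concentration, so all three amine side chains read alike. Nothing available bears on why these side chains read alike.

Open, going by these compounds, is whether a different group on this nitrogen, such as a longer chain, a cyclohexyl ring or a terminal carboxylic acid, would give a step beyond the scatter. Also open, on these data alone, is whether these three compounds would separate at a higher test concentration.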